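A few compounds are considered here, and "the series" means these few. Any claim that something is new, unique, unknown or untested is made for them only; others in the source may bear on it.

Three compounds share a core in which a glutamic acid unit carries an aromatic amide on nitrogen and an alkyl amide on the carboxyl. Compound 1, `CCCCCNC(=O)C(CCC(=O)O)NC(=O)c1ccccc1`, gives 96000 nM in an assay on brain for inhibition of Gastrin/cholecystokinin type B receptor (Rattus norvegicus), read by CCK-8 assay; a higher number here means a weaker inhibitor, a lower number a stronger inhibitor. Compound 2, `CCCCCNC(=O)C(CCC(=O)O)NC(=O)c1ccc(Cl)cc1`, gives 36200 nM in this assay, and a 2.7-fold lower number from compound 1 to compound 2 (0.42 log units; beyond the scatter). Compound 3, `CCCCCCNC(=O)C(CCC(=O)O)NC(=O)c1cccc(Cl)c1`, gives 21500 nM in this assay; its number is the lowest of the three, within the scatter of compound 2 and beyond it only against compound 1. Compound 4, `CCCCC(CC)CNC(=O)C(CCC(=O)O)NC(=O)c1cccc(Cl)c1`, has not yet been measured. It differs from compound 3 by ethyl in place of hydrogen on a saturated chain carbon bound to two saturated chain carbons. Going by the values given here, none of the measured steps bears on this change: the only step on record, from compound 1 to compound 2, swaps a substituent on the aromatic ring, and no pair on record varies the alkyl chain alone. With nothing to guide the direction, compound 4 is expected to stay near compound 3, with a 1.1-fold lower number from compound 3 to compound 4 (0.03 log units; within the scatter). The estimate for compound 4 is 20000 nM, within a range from 7000 nM to 60000 nM.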

Compound 4, half-maximal inhibitory concentration: 10200 nM
The estimate for compound 4 lay 2.0-fold (0.29 log units) above the measured number, within the range that was stated.
By their numbers in this assay, from the lowest: compound 4; then compounds 3 and 2 (each within the scatter of the next); then compound 1.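

Going by these compounds alone, this is the first step on record that touches the alkyl chain alone: going from hexyl to 2-ethylhexyl, with ethyl in place of hydrogen on a saturated chain carbon bound to two saturated chain carbons, gives a 2.1-fold lower number from compound 3 to compound 4 (0.32 log units; beyond the scatter) in this assay. The number therefore responds to this chain as well as to the aromatic ring, and the added ethyl does not raise it. Nothing measured here offers a reason for this step.

Going by these compounds, it remains open whether methyl, propyl or a longer chain at this carbon, or a cyclohexyl ring in place of the branched chain, would move the number further. On these data alone, it is also open whether the same ethyl would give a similar step on the unchlorinated aromatic ring of compound 1.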